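Picolinamide series: an ortho (pyridin-3-yl)amino analogue of compound 2

The compounds below may be only part of what the source reports. "The series", "measured", "known", "first", "only" and "open" are said of these compounds alone.

Measured so far in an assay on Ltk cells for inhibition of metabotropic glutamate receptor 5 (Homo sapiens), read by fluorescence; a higher number here means a weaker inhibitor, a lower number a stronger inhibitor:
compound 1, `O=C(Nc1ccccn1)c1cncc(Cl)n1`, gives 254 nM
compound 2, `Cc1cccc(NC(=O)c2cccc(C)n2)n1`, gives 32 nM
compound 3, `Cc1cccc(NC(=O)c2cccc(Br)n2)n1`, gives 21 nM

Compound 2 stands second highest of the three numbers in this assay. Its nearest neighbour is compound 3, reached by a 1.5-fold lower number from compound 2 to compound 3 (0.18 log units; within the scatter), a step that stays within the scatter. Compound 1, with its different core substitution, lies furthest from compound 2; its number is markedly higher, beyond the scatter.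

Compound 4, `Cc1cccc(NC(=O)c2nc(C)ccc2Nc2cccnc2)n1`, is not yet measured. It differs from compound 2 by (pyridin-3-yl)amino in place of hydrogen on an aromatic carbon. Within the data shown here, none of the measured steps touches this position or introduces a group of this kind: the only single-point step available, bromo for methyl, changes a substituent elsewhere on the core and is within the scatter, so it gives no guidance on the size or direction of the present change. Among the measured compounds shown here, with no bearing step, the expectation for compound 4 rests on the value of compound 2 alone, with a wide range in both directions. Compound 4 is therefore estimated at 60 nM, between 10 nM and 400 nM, which means an expected step of a 1.9-fold higher number from compound 2 to compound 4 (0.27 log units; within the scatter).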

Compound 4, half-maximal inhibitory concentration: 11 nM
The estimate for compound 4 lay 5.5-fold (0.74 log units) above the measured number, within the range that was stated.
By their numbers in this assay, from the lowest: compounds 4, 3 and 2 (each within the scatter of the next, the first and the last beyond it); then compound 1.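

In this assay, the aromatic carbon ortho to a large group and para to a methyl group accepts a substituent far larger than hydrogen without loss of inhibition: (pyridin-3-yl)amino there gives a 2.9-fold lower number from compound 2 to compound 4 (0.46 log units; beyond the scatter), a modest gain. Among these compounds, compounds 2 and 3 both carry hydrogen on this carbon, so the earlier data described only the bromo and methyl swap elsewhere on the core, and compound 4 is the first evidence that substitution at this position can move the number at all, and here in the favourable direction. No measurement shown bears on the reason for this step.

Going by these compounds, the result rests on a single substituent at this carbon, so it remains open whether the step belongs to the pyridine ring or to the linking amino nitrogen; a phenylamino group, a plain amino group or a methoxy group here would help to separate the two. Also open, on these data alone, is whether (pyridin-3-yl)amino gives a step of similar size on the bromo-bearing core of compound 3.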